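A few compounds are considered here, and "the series" means these few. Any claim that something is new, unique, unknown or untested is made for them only; others in the source may bear on it.

Measured compounds:
- Compound 1 `C=C1C[C@@H](OC(=O)C2=C(C)OC2)[C@@H](C(C)C)[C@@H]2[C@@H](C(C)=O)[C@@H](OC(=O)/C(C)=C\C)C[C@@H]12`: in a functional assay on MCF7 cells (Homo sapiens) for cytotoxicity (a lower number here means a stronger inhibitor, a higher number a weaker inhibitor), compound 1 gives > 100000 nM, which is a limit of the assay and not a number.
- Compound 2 `C/C=C(/C)C(=O)O[C@H]1C[C@@H](O)C2=CC(=O)C(=C(C)C)C[C@]2(C)[C@H]1C`: in this assay compound 2 gives > 100000 nM, again only a limit of the assay.

Compound 2 therefore stands at the edge of what this assay can report, and it is not alone there: the limit of > 100000 nM in this assay, at which 2 of the 2 values shown sit. Within the data shown here, no step between measured compounds can be drawn, since the two structures differ in many places and both values are limits.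

Compound 3 `C/C=C(/C)C(=O)O[C@H]1C[C@@H](OC(=O)/C(C)=C/C)C2=CC(=O)C(=C(C)C)C[C@]2(C)[C@H]1C` is the next compound to be tested in this assay. It differs from compound 2 in one place: (1-methylprop-1-en-1-yl)carbonyl in place of hydrogen on an oxygen on a saturated carbon. The hydroxy of compound 2 thus becomes ((1-methylprop-1-en-1-yl)carbonyl)oxy in compound 3.

Among the measured compounds shown here, with no measured step to lean on and compound 2 sitting at a limit, the expectation for compound 3 is a step of a number no higher from compound 2 to compound 3 (the limit leaves the size open), that is, none beyond the scatter, and most likely another limit. Compound 3 is estimated at 100000 nM in this assay, with a range from 20000 nM to 300000 nM.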

Compound 3, half-maximal inhibitory concentration: 21000 nM
Compound 3: middle estimate off by 4.8-fold (0.68 log units), on the high side; the measured number falls inside the stated range.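

In this assay, among these compounds, the position carrying the hydroxy on a saturated carbon is the first place where a single change is seen to move the read-out: putting (1-methylprop-1-en-1-yl)carbonyl in place of the hydrogen on that oxygen gives an at least 4.7-fold lower number from compound 2 to compound 3 (0.67 log units; beyond the scatter). Compound 3 thus brings the first true number among the compounds shown, so the free hydroxy is not required for a measurable result in this assay. The true size of the step cannot be given, because the value of compound 2 is a limit of the assay and not a number: the limit of > 100000 nM in this assay, at which 2 of the 3 values shown sit.

The compounds shown leave open whether this shift belongs to the (1-methylprop-1-en-1-yl)carbonyl group itself or would also appear with an acetyl, a benzoyl or a simple methyl on the same oxygen. With this single step in view, they also leave open how far the number can fall through changes at this position.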